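Phenyl Gives Way to Amino on a Shared Core

A few compounds are considered here, and "the series" means these few. Any claim that something is new, unique, unknown or untested is made for them only; others in the source may bear on it.

Three compounds have been measured so far in a physicochemical assay for solubility, in phosphate buffer, with a stated time of 18 h, at pH 7.4 (a lower number here means a less soluble compound, a higher number a more soluble compound), with these results:

- Compound 1 `Nc1nc(-c2ccccc2)nn1-c1ncnc2ccccc12` gives 1000 nM here
- Compound 2 `COc1cc2ncnc(-n3nc(-c4ccccc4)nc3N)c2cc1OC` gives 1000 nM here
- Compound 3 `CCN(CC)c1nc(-n2nc(-c3ccccn3)nc2N)c2cc(OC)c(OC)cc2n1` gives 6000 nM here

Compound 1 and compound 2 stand level, within the usual scatter, and together they hold the lowest number of the three. Compound 3 reads clearly higher, beyond the scatter, with a number well above that of compound 2.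

Compound 4 `COc1cc2ncnc(-n3nc(N)nc3N)c2cc1OC` has not been measured yet. Compared with compound 2, it has amino in place of phenyl on an aromatic carbon and that carbon lies between two ring nitrogen atoms.

Among the compounds with values here, no two measured compounds differ in only one place, so no measured step speaks directly to this change. Compound 3 at 6000 nM is the only sign of how far a number can rise among these compounds, so a moderate rise rather than a very large one is expected in this assay for this change. The expected step is a 4.0-fold higher number from compound 2 to compound 4 (0.60 log units; beyond the scatter) by this estimate. Compound 4 is expected to read 4000 nM as an estimate, within an estimated range from 1000 nM to 20000 nM at its two ends.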

Compound 4, solubility: 83000 nM
Estimate against measurement, compound 4: 21-fold (1.32 log units) below; measured number outside the range, above it.
By their numbers in this assay, from the lowest: compounds 1 and 2 (each within the scatter of the next); then compound 3; then compound 4.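

Within the data shown here, this is the first step between two measured compounds that differ in one place, and it shows that the group on this aromatic carbon, which lies between two ring nitrogen atoms, can move the read-out a long way. In this assay, among these compounds, the swap of phenyl for amino gives an 83-fold higher number from compound 2 to compound 4 (1.92 log units; beyond the scatter) on the shared core, a large step that the earlier compounds, none of them a one-place pair, could not reveal. The swap takes away a six-membered aromatic ring of 6 carbon atoms and puts in a group of 1 nitrogen atom, but nothing measured on these compounds accounts for the size of the step.

A single step cannot separate what leaving phenyl contributes from what entering amino contributes, so a small group such as methyl or a larger amine such as morpholine on the same carbon would be needed to tell the two apart. As far as these compounds go, it also stays open whether amino in place of phenyl would bring a similar step on the core of compound 1, or on the diethylamino-bearing core of compound 3 with its pyridine-type ring in the phenyl's place.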